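From Compound 2 to Compound 3: One Group Exchanged

This account rests on a few compounds, and the source may have more. Where it says the series, first, only, none or still open, it means among the compounds named here.

In a functional assay on HL-60 cells (Homo sapiens) for inhibition, read by CCK-8 assay, with a stated time of 48 h (a higher number here means a weaker inhibitor, a lower number a stronger inhibitor), compound 1 (`Cc1cc(C)cc(NC(=O)NCCNS(=O)(=O)c2ccc(-c3ccccc3OCc3ccccc3)s2)c1`) gives 2200 nM and compound 2 (`O=[N+]([O-])c1cccc(NC(=S)NCCNS(=O)(=O)c2ccc(-c3ccccc3OCc3cccc(O)c3)s2)c1`) gives 11400 nM. Compound 2 therefore has the higher of the two numbers, making it the weaker inhibitor by a margin beyond the scatter. Compound 3 (`Cc1cc(C)cc(NC(=O)NCCNS(=O)(=O)c2ccc(-c3ccccc3OCc3cccc(O)c3)s2)c1`) has not yet been measured. It differs from compound 2 by one exchange: a group of 11 heavy atoms (9 carbon, 1 nitrogen, 1 oxygen; one six-membered aromatic ring of carbon only) in place of a group of 12 heavy atoms (7 carbon, 2 nitrogen, 2 oxygen, 1 sulfur; one six-membered aromatic ring of carbon only), on an amine nitrogen. The entering (3,5-dimethylphenyl)carbamoyl group is also carried by compound 1, which gives 2200 nM, so a move toward that number is expected. Within the data shown here, no measured step isolates this exchange, which leaves the expectation uncertain. In this assay, the expected change is a 3.3-fold lower number from compound 2 to compound 3 (0.51 log units; beyond the scatter), a lower number by a margin beyond the scatter. The estimated value for compound 3 is 3500 nM, within a range of 1200 nM to 9000 nM.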

Compound 3, half-maximal inhibitory concentration: > 20000 nM
Compound 3 ended at the assay's limit; the forecaster's own chance of this, stated with the estimate: 3%; middle value at least 5.7-fold (0.75 log units) away from the limit.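

In this assay, the result for compound 3 is a limit of the assay and not a number: the limit of > 20000 nM in this assay, at which 1 of the 3 values shown sits.

Hydroxy in place of hydrogen on an aromatic carbon, the only difference from compound 1, gives an at least 9.0-fold higher number from compound 1 to compound 3 (0.95 log units; beyond the scatter), so this single exchange weakens inhibition by a margin beyond the scatter. The (3,5-dimethylphenyl)carbamoyl group on the amine nitrogen, exchanged for the group of compound 2, gives an at least 1.7-fold higher number from compound 2 to compound 3 (0.24 log units; that floor lies within the scatter), so with the hydroxy present this group does not bring the lower number seen for compound 1.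

Going by these compounds, how far compound 3 lies past the limit remains unknown, which leaves the true size of both steps open. The compounds shown also do not tell whether a methoxy or an amine on that aromatic carbon would give the same loss.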